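Aryl guanidines at the sigma-1 site: working notes

This account rests on a few compounds, and the source may have more. Where it says the series, first, only, none or still open, it means among the compounds named here.

Measured so far:
- compound 1 `COc1ccccc1NC(=N)Nc1ccccc1OC` — 1990 nM
- compound 2 `CN(C(=N)Nc1cccc2ccccc12)c1cccc2ccccc12` — 4800 nM

In an assay on membranes from brain (Cavia porcellus) for binding affinity to Sigma non-opioid intracellular receptor 1 (Homo sapiens), read by radioligand binding (a higher number here means a weaker inhibitor, a lower number a stronger inhibitor), compound 2 gives 4800 nM, the higher of the two numbers, with compound 1 at 1990 nM set apart beyond the scatter. Compound 3 `CN(C(=N)N(c1ccccc1)c1cccc2ccccc12)c1cccc2ccccc12` is not yet measured; it differs from compound 2 by phenyl in place of hydrogen on a nitrogen on an aromatic ring. Within the data shown here, no measured pair shows this change, so the expectation rests on compound 2 alone. The step from compound 2 to compound 3 is expected to be a 1.3-fold higher number from compound 2 to compound 3 (0.10 log units; within the scatter), likely no shift beyond the scatter, if anything toward a weaker inhibitor. Compound 3 is estimated at 6000 nM, within 2000 nM to 20000 nM.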

Compound 3, half-maximal inhibitory concentration: 11000 nM
Beside the measured number, compound 3's estimate is 1.8-fold (0.26 log units) below it; low and high end bracket the measured number.
By their numbers in this assay, from the lowest: compound 1; then compound 2; then compound 3.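

Phenyl in place of hydrogen on a nitrogen on an aromatic ring gives a 2.3-fold higher number from compound 2 to compound 3 (0.36 log units; beyond the scatter) in this assay, a modest step toward a weaker inhibitor. Among these compounds, this is the first reading of a change at this nitrogen, and it shows that the hydrogen cannot be replaced by phenyl without a shift beyond the scatter. No measurement at hand gives a reason for the shift.

From the compounds shown here alone, whether an ethyl or a benzyl group at this nitrogen moves the number the same way stays open. This single pair also leaves open whether phenyl has the same effect on the core of compound 1.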